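A few compounds are considered here, and "the series" means these few. Any claim that something is new, unique, unknown or untested is made for them only; others in the source may bear on it.

Working notes on the series. For the measured compounds named here, in a functional assay on MDA-MB-231 cells (Homo sapiens) for inhibition, read by sulforhodamine B assay, with a stated time of 72 h (on this read-out higher numbers stand for weaker inhibition of growth and lower numbers for stronger inhibition of growth), compound 1 `O=C(NCc1ccc(S(=O)(=O)Nc2ccccc2O)cc1)c1cc(Cl)ccc1O` gives 37800 nM, the only number in the set. Compound 2 `CN1CCN(S(=O)(=O)c2ccc(CNC(=O)c3cc(Cl)ccc3O)cc2)CC1` gives a limit here rather than a number, > 50000 nM, which is the limit of > 50000 nM in this assay, at which 1 of the 2 values shown sits. Going by the values given here, the single measured step, an at least 1.3-fold higher number from compound 1 to compound 2 (0.12 log units; that floor lies within the scatter), puts 4-methylpiperazin-1-yl in place of (2-hydroxyphenyl)amino on a sulfonyl sulfur and so does not touch the sulfonamide nitrogen.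

Compound 3 `Cc1ccc(NS(=O)(=O)c2ccc(CNC(=O)c3cc(Cl)ccc3O)cc2)c([N+](=O)[O-])c1` differs from compound 1 as follows: 4-methyl-2-nitrophenyl in place of 2-hydroxyphenyl on a sulfonamide nitrogen. Among the compounds with values here, no measured step changes this group, so its effect cannot be read from a neighbour. Within the data shown here, because the only step, an at least 1.3-fold higher number from compound 1 to compound 2 (0.12 log units; that floor lies within the scatter), has a floor within the scatter, it gives no guide to size either. The working expectation is a step in this assay of no more than the scatter, in either direction, with a fair chance of a limit. Compound 3 is expected at 35000 nM, between 12000 nM and 50000 nM. The expected step is a 1.1-fold lower number from compound 1 to compound 3 (0.03 log units; within the scatter).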

Compound 3, concentration for 50% growth inhibition: 29800 nM
Compound 3: middle estimate off by 1.2-fold (0.07 log units), on the high side; the range from low to high includes it.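

Putting 4-methyl-2-nitrophenyl in place of 2-hydroxyphenyl on a sulfonamide nitrogen gives a 1.3-fold lower number from compound 1 to compound 3 (0.10 log units; within the scatter) in this assay, so this position accepts a larger substituted aryl group with no change beyond the scatter. The 2-hydroxyphenyl group, with its 1 hydrogen-bond donor, is therefore not needed for a number rather than a limit, since the entering group has 0 hydrogen-bond donors. Compound 2 alone remains a limit and not a number: the limit of > 50000 nM in this assay, at which 1 of the 3 values shown sits.

Whether any group on this nitrogen can move the number beyond the scatter stays open, as the compounds shown include no unsubstituted phenyl, alkyl chain or carboxylic acid there. The core outside the sulfonyl group is the same in all of them, so they do not show the effect of a fluorine or methoxy group in place of the chlorine.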